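A few compounds are considered here, and "the series" means these few. Any claim that something is new, unique, unknown or untested is made for them only; others in the source may bear on it.

Compound 3 `Cc1cnn(C(=O)N(C)CCN(C)Cc2cccc(OCc3ccccc3)c2)c1` is one of two compounds with a number in an assay on membranes from brain for binding affinity to Monoacylglycerol lipase ABHD6 (Mus musculus), read by fluorescence, with stated times of 1 h and 30 min; a lower number here means a stronger inhibitor, a higher number a weaker inhibitor. In this assay compound 3 gives 8300 nM, which is the higher of the two numbers, so it is the weaker inhibitor of the pair. The nearer neighbour, compound 2 `O=C(N1CCCN(Cc2ccc(OCc3ccccc3)cc2)CC1)n1cccn1`, is built on the same benzyloxy-substituted benzyl motif but carries its carbamoyl pyrazole on a saturated seven-membered diamine ring; in this assay compound 2 gives 960 nM. Compound 1 `O=C(NCc1ccc(OCc2ccccc2)cc1)n1cccn1`, the simplest member with an open amide to the benzylic carbon, has in this assay only the entry "not determined" (no result reported), so no number is known for it.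

Compound 4 `CN(CCN(C)C(=O)n1cc(C#N)cn1)Cc1cccc(OCc2ccccc2)c1` keeps the whole open-chain diamine of compound 3 and changes only the substituent on the five-membered aromatic ring: cyano in place of methyl on an aromatic carbon. Within the data shown here, no step between two measured compounds shows what this exchange does, so the expectation rests on compound 3 alone. A modest move toward a lower number is expected for compound 4, with the step from a 3.3-fold lower number from compound 3 to compound 4 (0.52 log units; beyond the scatter) meant as the expected size. Compound 4 is therefore estimated at 2500 nM, within a range of 600 nM to 12000 nM.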

Compound 4, half-maximal inhibitory concentration: 1100 nM
For compound 4 the middle estimate is 2.3-fold (0.36 log units) above the measured one; low and high end bracket the measured number.
By their numbers in this assay, from the lowest: compounds 2 and 4 (each within the scatter of the next); then compound 3.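

With the open-chain diamine held fixed, the group on this aromatic carbon of the five-membered ring proves to matter in this assay: cyano in place of methyl gives a 7.5-fold lower number from compound 3 to compound 4 (0.88 log units; beyond the scatter), so the move from 4-methyl-1H-pyrazol-1-yl to 4-cyano-1H-pyrazol-1-yl counts for more than the usual scatter. The earlier compounds shown here could not show this, as no pair among them differed in one place only. Nothing given here explains the step.

Whether cyano is special at this position stays open, since only methyl and cyano are shown there, and a chlorine, a carboxamide or a bare ring hydrogen could place the result in context. As far as these compounds go, it also remains open whether the same exchange would lower the number on the core of compound 2.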